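This account rests on a few compounds, and the source may have more. Where it says the series, first, only, none or still open, it means among the compounds named here.

Compound 2 `O=C1C(=O)N(CC(CO)NCCNc2ccnc3cc(Cl)ccc23)c2ccc(Cl)cc21` carries a chloro on each of its two aromatic ring systems. In an ADME assay on HCT-116 cells (Homo sapiens) for cytotoxicity, read by MTT assay, with a stated time of 48 h, tested at 20 uM (on this read-out higher numbers stand for a stronger effect at the one concentration tested and lower numbers for a weaker effect), compound 2 gives 88%, the highest of the three numbers measured. Compound 3 `O=C1C(=O)N(CC(CO)NCCCNc2ccnc3cc(Cl)ccc23)c2ccc(F)cc21` gives 66%, and compound 1 `O=C1C(=O)N(CC(CO)NCCCNc2ccnc3cc(Cl)ccc23)c2ccc(Cl)cc21` gives 46%. Within the data shown here, the only step between measured compounds that differ in one place, a number 20 percentage points higher from compound 1 to compound 3 (beyond the scatter), also changed a halogen on an aromatic carbon. Compound 4 `O=C1C(=O)N(CC(CO)NCCNc2ccnc3cc(Cl)ccc23)c2ccccc21` differs from compound 2 by hydrogen in place of chloro on an aromatic carbon. That earlier step shows a halogen change at such a carbon can shift the number, but it swapped one halogen for another rather than removing it, so the direction is uncertain. The expected step is a number 13 percentage points lower from compound 2 to compound 4 (beyond the scatter), a small fall. Compound 4 is estimated at 75%, within a range from 50% to 95%.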

Compound 4, a percentage reported as inhibition, at one concentration (the size of the read-out at that concentration, not a potency): 91%
For compound 4 the middle estimate is 16 percentage points below the measured one; the range from low to high includes it.
By their numbers in this assay, from the lowest: compound 1; then compound 3; then compounds 2 and 4 (each within the scatter of the next).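

In this assay, taking the chloro away from this aromatic carbon altogether gives a number 3 percentage points higher from compound 2 to compound 4 (within the scatter), so the chloro is not needed here to hold the number in this pair. The earlier halogen step, a number 20 percentage points higher from compound 1 to compound 3 (beyond the scatter), came from swapping one halogen for another on a different chain, and it could not show what having no halogen at all would do. No measurement shown here explains this result.

As far as these compounds go, whether hydrogen in place of chloro would also leave the number unchanged in compound 1 remains open. So does the effect of a methoxy or a nitrile at this same carbon.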